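The source may hold more compounds than are shown below. What is called first, only, known or untested is meant among the compounds shown, and "the series" means these compounds.

In a functional assay on HepG2 cells (Homo sapiens) for inhibition, read by MTT assay, with a stated time of 72 h (on this read-out higher numbers stand for weaker inhibition and lower numbers for stronger inhibition), compound 1 `O=C(Nc1ccccc1)C1CCN(C/C=C/c2ccccc2)CC1` gives 90900 nM and compound 2 `Cc1ccc(NC(=O)C2CCN(C/C=C/c3ccccc3)CC2)cc1` gives 33900 nM while compound 3 `CC(C)c1ccc(NC(=O)C2CCN(C/C=C/c3ccccc3)CC2)cc1` gives 12200 nM as the lowest number of the three. Next comes compound 4 `CCCCCc1ccc(NC(=O)C2CCN(C/C=C/c3ccccc3)CC2)cc1` with the change pentyl in place of isopropyl on an aromatic carbon in which pentyl takes the place of isopropyl on an aromatic carbon. Among the compounds with values here, two measured steps bear on this: a 2.7-fold lower number from compound 1 to compound 2 (0.43 log units; beyond the scatter) and a 2.8-fold lower number from compound 2 to compound 3 (0.44 log units; beyond the scatter) are both modest and beyond the scatter, and together they give a 7.5-fold lower number from compound 1 to compound 3 (0.87 log units; beyond the scatter) overall. In each, a larger group replaces a smaller one at this place. Pentyl itself remains untested, so the trend may not hold. The expected step of a 2.2-fold lower number from compound 3 to compound 4 (0.35 log units; beyond the scatter) is again modest and toward a lower number in this assay. For compound 4 the estimated value is 5500 nM within an expected range from 2000 nM to 14000 nM for now.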

Compound 4, half-maximal inhibitory concentration: 2890 nM
Estimate against measurement, compound 4: 1.9-fold (0.28 log units) above; low and high end bracket the measured number.
By their numbers in this assay, from the lowest: compound 4; then compound 3; then compound 2; then compound 1.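

In this assay, pentyl extends the run of lower numbers at this place beyond isopropyl, with a 4.2-fold lower number from compound 3 to compound 4 (0.63 log units; beyond the scatter), so no levelling off appears up to pentyl. Within the data shown here, the first large steps at this position appear here, a 12-fold lower number from compound 2 to compound 4 (1.07 log units; beyond the scatter) and a 31-fold lower number from compound 1 to compound 4 (1.50 log units; beyond the scatter), and all four compounds fall in order of increasing size of the group. No measured data on these compounds explain the trend. As far as these compounds go, whether a longer chain such as octyl continues the run stays open, as does whether a carboxylic acid or an amine at this place fits it.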